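Changing the aryl group on an aromatic nitrogen of compound 1

This account rests on a few compounds, and the source may have more. Where it says the series, first, only, none or still open, it means among the compounds named here.

Going by the values given here, compound 1 `COc1ccc([C@@H]2C/C(=N/OCc3cn(-c4cccc(CO)c4)nn3)c3cc(CC=C(C)C)c(OC)cc3O2)cc1` is one of two compounds measured here. In a functional assay on A549 cells (Homo sapiens) for inhibition, read by sulforhodamine B assay, with a stated time of 48 h, tested at 50 uM (on this read-out lower numbers stand for less inhibition of growth and higher numbers for more inhibition of growth at the one concentration tested), compound 1 gives 43%, the lower of the two numbers. Compound 2 `COc1ccc([C@@H]2C/C(=N/O)c3cc(CC=C(C)C)c(OC)cc3O2)cc1` gives 66% in this assay, a result that lies above that of compound 1 by more than the usual scatter. Compound 1 and compound 2 differ in more than one place, so this gap is not assigned to any single change.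

Compound 3 `COc1ccc([C@@H]2C/C(=N/OCc3cn(-c4ccc(NC(C)=O)cc4)nn3)c3cc(CC=C(C)C)c(OC)cc3O2)cc1` has not been measured. It differs from compound 1 in one way: 4-acetamidophenyl in place of 3-(hydroxymethyl)phenyl on an aromatic nitrogen. Among the compounds with values here, no pair of measured compounds that differ in a single place is available, so there is no direct precedent for a change of this kind. Within the data shown here, because the only measured anchor for compound 3 is compound 1 at 43%, compound 3 is expected to land close to it, with a step of a number 2 percentage points higher from compound 1 to compound 3 (within the scatter) that is small and within the scatter. The estimate for compound 3 is 45%, with a range from 25% to 65%.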

Compound 3, percent growth inhibition at one concentration: 19%
The estimate for compound 3 lay 26 percentage points above the measured number; the whole stated range lies above it.
By their numbers in this assay, from the lowest: compound 3; then compound 1; then compound 2.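

In this assay, going by these compounds alone, the aryl group on the aromatic nitrogen of the five-membered ring is not a silent position: 4-acetamidophenyl in place of 3-(hydroxymethyl)phenyl gives a number 24 percentage points lower from compound 1 to compound 3 (beyond the scatter), the first reading of a change in one place in this set. The two groups match in having one six-membered aromatic ring of carbon only, 1 hydrogen-bond donor, 1 hydrogen-bond acceptor and no net charge, so these shared features alone do not keep the number in place; the entering group differs in having 10 heavy atoms rather than 8, a nitrogen and a double bond outside aromatic rings. No measurement here accounts for the lower growth inhibition, so the step stands as an observation only.

This one step swaps the substituent and also changes where it sits on the phenyl ring, and the compounds shown do not separate those two changes. From the compounds shown here alone, it also remains open where a plain phenyl group, or a phenyl group carrying an amine or a carboxylic acid, would fall relative to compound 1 and compound 3.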